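The compounds below may be only part of what the source reports. "The series", "measured", "known", "first", "only" and "open" are said of these compounds alone.

In an in vitro ADME assay on microsomes from liver (Homo sapiens) for metabolic stability, tested at 5 uM (a higher number here means that the compound lasts longer, a lower number that the compound disappears faster), compound 3 `CS(=O)(=O)Nc1ccc2c(c1)S(=O)(=O)N=C(c1c(O)c(-c3cccs3)nn(CC3CC3)c1=O)N2` stands at > 1 h, which is a limit and not a number. Compound 1 `COC(C)(C)CCn1nc(-c2cccs2)c(O)c(C2=NS(=O)(=O)c3cc(NS(C)(=O)=O)ccc3N2)c1=O` gives > 1 h, also a limit. Compound 2 `CC(C)(C)Cn1nc(-c2cccs2)c(O)c(C2=NS(=O)(=O)c3cc(NS(C)(=O)=O)ccc3N2)c1=O` gives > 1 h, again a limit. What the series offers so far is therefore (the limit of > 1 h in this assay, at which 3 of the 3 values shown sit).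

Compound 4 `CS(=O)(=O)Nc1ccc2c(c1)S(=O)(=O)N=C(c1c(O)c(-c3cccs3)nn(CC3(C(F)(F)F)CCC3)c1=O)N2` differs from compound 3 as follows: 1-(trifluoromethyl)cyclobutyl in place of cyclopropyl on a saturated chain carbon bound to an aromatic nitrogen. In words, 1-(trifluoromethyl)cyclobutyl takes the place of cyclopropyl on a saturated chain carbon bound to an aromatic nitrogen.

The measured changes at this same place are the ones that bear on it. They are a step that the two limits leave unreadable from compound 2 to compound 3, a step that the two limits leave unreadable from compound 1 to compound 3 and a step that the two limits leave unreadable from compound 1 to compound 2. None of them offers a size to carry over, and no direction can be drawn from them. With all three compounds at the same limit, no shift beyond the scatter is expected, so the estimated change is a step that the limit leaves unreadable from compound 3 to compound 4. A further limit is the likeliest report in this assay. For compound 4 the estimated half-life is 1.5 h, with an expected range from 0.7 h to 4 h.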

Compound 4, half-life: 1 h
Beside the measured number, compound 4's estimate is 1.5-fold (0.18 log units) above it, within the range that was stated.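

In this assay, among the compounds shown here, compound 4 is the only one of the four compounds to give a number rather than a limit, so this position now has one reading that can be set against the others, though in one direction only. With 1-(trifluoromethyl)cyclobutyl on the saturated chain carbon bound to an aromatic nitrogen, the result is a number no higher from compound 3 to compound 4 (the limit leaves the size open), and the comparisons with the other two groups give a number no higher from compound 2 to compound 4 (the limit leaves the size open) and a number no higher from compound 1 to compound 4 (the limit leaves the size open). The size of these steps cannot be read, and neither can the steps among the other three compounds, since those compounds share one limit: the limit of > 1 h in this assay, at which 3 of the 4 values shown sit.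

From the compounds shown here alone, how far compound 1, compound 2 and compound 3 lie past that limit stays open. Also open, going by these compounds, is what an amine, a carboxylic acid or a longer chain at this place would give in this assay.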